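From 2-Fluorophenyl to 3-Chlorophenyl on an Amide Nitrogen

The compounds below may be only part of what the source reports. "The series", "measured", "known", "first", "only" and "open" are said of these compounds alone.

In a functional assay on T47D cells (Homo sapiens) for inhibition, read by CCK-8 assay, with a stated time of 72 h, tested at 10 uM (on this read-out higher numbers stand for more inhibition of growth at the one concentration tested and lower numbers for less inhibition of growth), compound 1 `CN(C)C(=O)c1cc2cnc(Nc3ccc(NC(=O)C4(C(=O)Nc5cccc(F)c5)CC4)cc3)nc2n1C1CCCC1` gives -0.4%, while compound 2 `CN(C)C(=O)c1cc2cnc(Nc3ccc(NC(=O)C4(C(=O)Nc5ccccc5F)CC4)cc3)nc2n1C1CCCC1` gives 97.8%, the higher of the two numbers. Placing 2-fluorophenyl in place of 3-fluorophenyl on an amide-type nitrogen accounts for a number 98.2 percentage points higher from compound 1 to compound 2 (beyond the scatter). Compound 3 `CN(C)C(=O)c1cc2cnc(Nc3ccc(NC(=O)C4(C(=O)Nc5cccc(Cl)c5)CC4)cc3)nc2n1C1CCCC1` carries 3-chlorophenyl in place of 2-fluorophenyl on an amide-type nitrogen. Among the compounds with values here, only that one measured step bears on this change. Its relevance is that 3-chlorophenyl shares its number with the 3-fluorophenyl of compound 1, which gave -0.4%. Within the data shown here, no measured pair shows what chlorine in place of fluorine does, so the expectation stays loose. A large fall in this assay is expected, as the estimated a number 67.8 percentage points lower from compound 2 to compound 3 (beyond the scatter). The expected value for compound 3 is 30%, with an estimated range of -5% to 90%.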

Compound 3, percent growth inhibition at one concentration: 92.6%
The estimate for compound 3 lay 62.6 percentage points below the measured number, and the stated range ends below it.
By their numbers in this assay, from the lowest: compound 1; then compounds 3 and 2 (each within the scatter of the next).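

In this assay, the change from 2-fluorophenyl to 3-chlorophenyl on the amide-type nitrogen gives a number 5.2 percentage points lower from compound 2 to compound 3 (within the scatter), so the two groups cannot be told apart here, and the read-out at this nitrogen does not simply follow the number in the group's name. The pair that shares that number separates sharply: chloro in place of fluoro on an aromatic carbon gives a number 93 percentage points higher from compound 1 to compound 3 (beyond the scatter), which ties the near-zero result of compound 1 to 3-fluorophenyl specifically, not to 3-halophenyl groups in general. Nothing available explains why these two halogens part so widely in this series.

Going by these compounds, it remains open how unsubstituted phenyl, 3-methylphenyl or 3-methoxyphenyl would behave on this nitrogen. On these data alone, since this assay uses a single concentration, it also remains open whether compound 2 and compound 3 would separate in a full dose-response curve.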